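Methoxy in place of trifluoromethyl on an aromatic carbon

The source may hold more compounds than are shown below. What is called first, only, known or untested is meant among the compounds shown, and "the series" means these compounds.

In a physicochemical assay for solubility, using the shake flask method, in simulated intestinal fluid, measured as kinetic solubility, with a stated time of 2 h, at 25 degrees C, at pH 6.5 (on this read-out higher numbers stand for higher solubility and lower numbers for lower solubility), compound 1 `Cc1noc(-c2nc(C)c3c(c2N)C(=O)N(CC2CCNCC2)C3=O)n1` gives 160000 nM. Compound 2 `Cc1noc(-c2nc(C)c3c(c2N)C(=O)N(Cc2ccc(C(F)(F)F)cc2)C3=O)n1` gives < 5000 nM, which is a limit of the assay and not a number. Going by the values given here, the only measured step, an at least 32-fold lower number from compound 1 to compound 2 (1.50 log units; beyond the scatter), is large and lies beyond the scatter; it puts 4-(trifluoromethyl)phenyl in place of piperidin-4-yl. Compound 3 `COc1ccc(CN2C(=O)c3c(C)nc(-c4nc(C)no4)c(N)c3C2=O)cc1` keeps the shared core but carries methoxy in place of trifluoromethyl on an aromatic carbon, para to a large group: methoxy in place of trifluoromethyl on an aromatic carbon. Among the compounds with values here, no measured step covers this swap directly. The piperidin-4-yl of compound 1 does not return, so the large step of an at least 32-fold lower number from compound 1 to compound 2 (1.50 log units; beyond the scatter) is expected to stay in place, and no further step beyond the scatter is expected in this assay. The estimated step is a step that the limit leaves unreadable from compound 2 to compound 3. For compound 3 the expected value is 4000 nM, with an estimated range from 1500 nM to 12000 nM.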

Compound 3, solubility: < 5000 nM
Compound 3 ended at the assay's limit; the forecaster's own chance of this, stated with the estimate: 65%; the middle value lies beyond the limit too.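

In this assay, 4-methoxyphenyl in place of piperidin-4-yl on the saturated chain carbon gives an at least 32-fold lower number from compound 1 to compound 3 (1.50 log units; beyond the scatter), a large step. The drop on leaving piperidin-4-yl is therefore not tied to trifluoromethyl, since it appears with methoxy on the same aromatic carbon as well, and neither compound 2 nor compound 3 goes against this. The step between trifluoromethyl and methoxy themselves cannot be read because both compounds stand at a limit of the assay and not at a number: the limit of < 5000 nM in this assay, at which 2 of the 3 values shown sit.

From the compounds shown here alone, how far past that limit either compound lies remains open. Also open, going by these compounds, is whether an amine or a carboxylic acid in place of methoxy on the aromatic ring would bring the number back above the limit.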